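The source may hold more compounds than are shown below. What is called first, only, known or untested is meant among the compounds shown, and "the series" means these compounds.

In an ADME assay on HEK293 cells (Homo sapiens) for cytotoxicity, with a stated time of 72 h (a higher number here means that more compound is needed for the effect, a lower number that less compound is needed), compound 3 (`Cc1ccc(-c2nc3ccccc3s2)cc1NC(=O)c1cc([N+](=O)[O-])ccc1Cl`) gives > 14000 nM as a limit and not a number. Compound 1 (`COc1ccc(-c2nc3ccccc3o2)cc1NC(=O)c1cc([N+](=O)[O-])ccc1Cl`) carries 1,3-benzoxazol-2-yl and gives > 25000 nM as a limit. Compound 2 (`O=C(Nc1cccc(-c2nc3ccccc3o2)c1)c1cc([N+](=O)[O-])ccc1Cl`) carries the same group and gives > 25000 nM as a limit too. Within the data shown here, the one measured step (a step that the two limits leave unreadable from compound 1 to compound 2) is hydrogen in place of methoxy on an aromatic carbon, and it leaves the group that changes next untouched. Among the measured compounds shown here, compound 4 (`Cc1ccc(-c2nc3ccccc3o2)cc1NC(=O)c1cc([N+](=O)[O-])ccc1Cl`) differs from compound 3 by 1,3-benzoxazol-2-yl in place of 1,3-benzothiazol-2-yl on an aromatic carbon and no measured step makes this exchange. The expectation therefore rests on compound 2 with its > 25000 nM limit, and no step beyond the scatter is expected in this assay for this exchange. The estimated step is a step that the limit leaves unreadable from compound 3 to compound 4 and its size stays uncertain among limits. Compound 4 is expected at 25000 nM with an estimated range from 12000 nM to 50000 nM and a report as a limit is likely.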

Compound 4, half-maximal effective concentration: > 14000 nM
Compound 4: no number, only a limit; the forecaster's own chance of this, stated with the estimate: 85%; the middle value is on the limit's open side.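

In this assay compound 4 gives > 14000 nM, a limit and not a number. Its steps from compound 1, compound 2 and compound 3 cannot be read, since all four values are limits. The compounds shown leave open whether 1,3-benzoxazol-2-yl in place of 1,3-benzothiazol-2-yl changes the half-maximal effective concentration at all.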